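Swapping ethoxy for (butylamino)methyl on compound 2's carbonyl

The source may report more compounds than this note shows. Statements on the series, on what has been measured and on what is new or still open speak of the compounds shown alone.

Among the compounds with values here, in a functional assay on the whole organism for inhibition, with Mus musculus as the target (a higher number here means that more compound is needed for the effect, a lower number that less compound is needed), compound 2 (`CCOC(=O)Nc1cccc2c1CN(C)CC2c1ccc(Cl)cc1`) gives 0.6 mg/kg, the lowest of the three numbers so far. Compound 3 (`CCOC(=O)Nc1cccc2c1CN(C)CC2c1ccc(F)cc1`) gives 3.3 mg/kg, and compound 1 (`CCCCNC(=O)Nc1cccc2c1CN(C)CC2c1ccc(Cl)cc1`) gives 15 mg/kg. Unmeasured compound 4 (`CCCCNCC(=O)Nc1cccc2c1CN(C)CC2c1ccc(Cl)cc1`) has (butylamino)methyl in place of ethoxy on a carbonyl carbon. The nearest evidence is a 25-fold lower number from compound 1 to compound 2 (1.40 log units; beyond the scatter), where ethoxy replaces butylamino on a carbonyl carbon. The other measured change, a 5.5-fold higher number from compound 2 to compound 3 (0.74 log units; beyond the scatter), lies on an aromatic carbon and bears on this one only as a measure of sensitivity. Ethoxy therefore leaves with a higher number expected, though the new group differs from butylamino. The expected change is a 10-fold higher number from compound 2 to compound 4 (1.00 log units; beyond the scatter). For compound 4 the estimate is 6 mg/kg, within an expected range of 1.5 mg/kg to 25 mg/kg.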

Compound 4, dose for half-maximal effect: 3.9 mg/kg
Compound 4: the middle estimate sits 1.5-fold (0.19 log units) above what was measured; the measured number falls inside the stated range.
By their numbers in this assay, from the lowest: compound 2; then compounds 3 and 4 (each within the scatter of the next); then compound 1.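

In this assay the carbonyl carbon responds to more than the swap of ethoxy for butylamino: (butylamino)methyl in place of ethoxy gives a 6.5-fold higher number from compound 2 to compound 4 (0.81 log units; beyond the scatter) and leaves ethoxy the best of the three groups here. Placing a methyl link between the carbonyl and the butylamino group recovers part of the loss, with a 3.8-fold lower number from compound 1 to compound 4 (0.59 log units; beyond the scatter) as the measure of that gain.

Still open, going by these compounds, is whether a shorter chain such as (methylamino)methyl, or a cyclic amine such as piperidine, would bring the number closer to that of ethoxy. Also open, on these data alone, is whether fluoro in place of chloro on an aromatic carbon changes the number to the same extent when (butylamino)methyl is present. Nothing available here explains these steps.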